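Glycosylated triazole indoles tested for breast cancer cell growth

The compounds below may be only part of what the source reports. "The series", "measured", "known", "first", "only" and "open" are said of these compounds alone.

Measured compounds:
compound 1 `COc1ccc2c(c1)c(/C=N/O)cn2Cc1cn([C@@H]2O[C@H](COC(C)=O)[C@@H](OC(C)=O)[C@H](OC(C)=O)[C@H]2OC(C)=O)nn1` with 51000 nM
compound 2 `CC(=O)OC[C@H]1O[C@@H](n2cc(Cn3cc([N+](=O)[O-])c4ccccc43)nn2)[C@H](OC(C)=O)[C@@H](OC(C)=O)[C@@H]1OC(C)=O` with > 200000 nM

For the measured compounds named here, in a functional assay on MCF7 cells (Homo sapiens) for cytotoxicity, read by sulforhodamine B assay, with a stated time of 48 h (on this read-out lower numbers stand for stronger inhibition and higher numbers for weaker inhibition), compound 1 gives 51000 nM, the only number. For compound 2 the value > 200000 nM is a limit of the assay and not a number (the limit of > 200000 nM in this assay, at which 1 of the 2 values shown sits). Compound 3 `COc1ccc2c(c1)c(/C=C1/C(=O)Nc3ccc(F)cc31)cn2Cc1cn([C@@H]2O[C@H](COC(C)=O)[C@@H](OC(C)=O)[C@H](OC(C)=O)[C@H]2OC(C)=O)nn1` differs from compound 1 by a group of 12 heavy atoms (9 carbon, 1 nitrogen, 1 oxygen, 1 fluorine; one five-membered non-aromatic ring with 1 hetero atom, one six-membered aromatic ring of carbon only) in place of a group of 3 heavy atoms (1 carbon, 1 nitrogen, 1 oxygen; no ring), on an aromatic carbon. Going by the values given here, no measured step of this kind exists here, so the expectation rests on compound 1 alone. A moderate gain is expected, the step from compound 1 to compound 3 estimated as a 3.4-fold lower number from compound 1 to compound 3 (0.53 log units; beyond the scatter). Compound 3 is expected to give 15000 nM, within 3000 nM to 80000 nM.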

Compound 3, half-maximal inhibitory concentration: > 200000 nM
Compound 3 was reported as a limit; the forecaster's own chance of this, stated with the estimate: 10%; at least 13-fold (1.12 log units) between middle value and limit.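

In this assay compound 3 gives > 200000 nM, a limit of the assay and not a number. At this aromatic carbon, exchanging the group of compound 1 for the larger two-ring group weakens the read-out, with an at least 3.9-fold higher number from compound 1 to compound 3 (0.59 log units; beyond the scatter), so a measurable value does not survive this change. Most of the series now sits at the same ceiling: the limit of > 200000 nM in this assay, at which 2 of the 3 values shown sit.

On these data alone, the full size of the step stays open. Also open, as far as these compounds go, is whether a nitrile or an amine on this aromatic carbon would keep a measurable value.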